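Trimming a butyl chain in a weak inhibitor series

A few compounds are considered here, and "the series" means these few. Any claim that something is new, unique, unknown or untested is made for them only; others in the source may bear on it.

Compound 2 `CCCCC1N(Cc2ccc(-c3ccccc3-c3nn[nH]n3)cc2)C(=O)c2ccccc2N1C` stands level with compound 1 `CCCCC1Nc2ccccc2C(=O)N1Cc1ccc(-c2ccccc2-c2nn[nH]n2)cc1`: in an assay on adrenal cortex for inhibition of angiotensinogen (Rattus norvegicus) (a lower number here means a stronger inhibitor, a higher number a weaker inhibitor), compound 1 gives 14000 nM, compound 2 gives 14000 nM, and the step from no change at the digits printed from compound 1 to compound 2 (within the scatter). Compound 3 `CCCC1N(Cc2ccc(-c3ccccc3-c3nn[nH]n3)cc2)C(=O)c2ccccc2N1C` is compound 2 with hydrogen in place of methyl on a saturated chain carbon, three bonds along the chain from a saturated ring carbon. Among the measured compounds shown here, no measured step touches this chain; the single step known here concerns a different place and shows nothing beyond the scatter, so it offers little guidance. The expected step in this assay is a 1.4-fold higher number from compound 2 to compound 3 (0.15 log units; within the scatter), a shift too small to trust. Compound 3 is therefore estimated at 20000 nM, within a wide range from 7000 nM to 60000 nM.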

Compound 3, half-maximal inhibitory concentration: 540 nM
For compound 3 the middle estimate is 37-fold (1.57 log units) above the measured one; measured number below the stated range.
By their numbers in this assay, from the lowest: compound 3; then compounds 1 and 2 (each within the scatter of the next).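

Shortening the butyl chain of compound 2 to the propyl chain of compound 3 gives, in this assay, a 26-fold lower number from compound 2 to compound 3 (1.41 log units; beyond the scatter). This chain is therefore a sensitive place in the molecule, where the loss of one carbon counts for much more than the earlier change on nitrogen did. No measurement at hand explains the gain.

Still open, from the compounds shown here alone, is whether an ethyl or methyl chain here would lower the number further or raise it again. Going by these compounds, it is also open whether propyl gives a similar gain in compound 1, which lacks the methyl on nitrogen.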